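The source may report more compounds than this note shows. Statements on the series, on what has been measured and on what is new or still open speak of the compounds shown alone.

Compound 1: `COc1ccccc1-n1c(-c2coc3cc(C)c(Cl)cc3c2=O)nc(-c2ccccc2)c1-c1ccccc1` gives 12500 nM in a functional assay on HepG2 cells (Homo sapiens) for inhibition, read by MTT assay, with a stated time of 72 h; a lower number here means a stronger inhibitor, a higher number a weaker inhibitor.
Compound 2: `Cc1cc2occ(-c3nc(-c4ccccc4)c(-c4ccccc4)n3-c3cccc(Cl)c3)c(=O)c2cc1Cl` gives 25000 nM in this assay.

Compound 2 shows the highest of these two numbers, though the gap between them is a 2.0-fold higher number from compound 1 to compound 2 (0.30 log units; within the scatter), which is within the scatter. Compound 3 is `Cc1cc2occ(-c3nc(-c4ccccc4)c(-c4ccccc4)n3-c3cccc([N+](=O)[O-])c3)c(=O)c2cc1Cl`. The change from compound 2 is nitro in place of chloro on an aromatic carbon. For the measured compounds named here, no measured step swaps these two groups, and the one known step, from a different group exchange on the same position, stayed within the scatter. No step beyond the scatter is therefore expected in this assay for compound 3, with a step of no change at the digits printed from compound 2 to compound 3 (within the scatter). Compound 3 is estimated at 25000 nM, between 10000 nM and 60000 nM.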

Compound 3, half-maximal inhibitory concentration: 25000 nM
Estimate against measurement, compound 3: no gap at the digits printed; measured number inside the range.
By their numbers in this assay, from the lowest: compounds 1, 2 and 3 (each within the scatter of the next).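

For the compounds shown here, the swap of 3-chlorophenyl to 3-nitrophenyl gives no change at the digits printed from compound 2 to compound 3 (within the scatter) in this assay and is the first comparison here of two groups at the same place on this ring, so a larger group of three heavy atoms leaves the reading unmoved. Measured against the 2-methoxyphenyl compound, the nitro compound shows a 2.0-fold higher number from compound 1 to compound 3 (0.30 log units; within the scatter) and so also stays close. No other measurement offers an explanation for this flat result. As far as these compounds go, whether an amine or a carboxylic acid at this place would give a step beyond the scatter remains open.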